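The source may report more compounds than this note shows. Statements on the series, on what has been measured and on what is new or still open speak of the compounds shown alone.

Measured so far in a functional assay on HL-60 cells (Homo sapiens) for inhibition; on this read-out lower numbers stand for stronger inhibition and higher numbers for weaker inhibition:
Compound 1 `COc1ccc(-c2cc(=O)n(C)nc2-c2ccc(OC)cc2)cc1` gives 1130 nM.
Compound 2 `COc1ccc(-c2cc(=O)n(C3CCCC3)nc2-c2ccc(OC)cc2)cc1` gives 510 nM.
Compound 3 `COc1ccc(-c2cc(O)nnc2-c2ccc(OC)cc2)cc1` gives 31600 nM.

Compound 2 stands lowest of the three numbers. Its nearest neighbour is compound 1, reached by a 2.2-fold lower number from compound 1 to compound 2 (0.35 log units; beyond the scatter); compound 3 lies far above both values. Compound 4 `COc1ccc(-c2cc(=O)n(CC3CCCC3)nc2-c2ccc(OC)cc2)cc1` is not yet measured. Compared with compound 2 it carries cyclopentylmethyl in place of cyclopentyl on an aromatic nitrogen. Among the measured compounds shown here, only one measured step bears on this place: the change from compound 1 to compound 2, which gave a 2.2-fold lower number from compound 1 to compound 2 (0.35 log units; beyond the scatter) when the group on the aromatic nitrogen grew from methyl to cyclopentyl. Adding one more carbon to reach cyclopentylmethyl is a smaller change than that, so a step within the scatter or a slight further lowering is expected. Compound 4 is therefore estimated at 400 nM, with a range of 150 nM to 1200 nM. The expected step is a 1.3-fold lower number from compound 2 to compound 4 (0.11 log units; within the scatter).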

Compound 4, half-maximal inhibitory concentration: 110 nM
Beside the measured number, compound 4's estimate is 3.6-fold (0.56 log units) above it; measured number outside the range, below it.
By their numbers in this assay, from the lowest: compound 4; then compound 2; then compound 1; then compound 3.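

In this assay, cyclopentylmethyl in place of cyclopentyl gave a 4.6-fold lower number from compound 2 to compound 4 (0.67 log units; beyond the scatter), although both groups carry the same five-membered carbon ring, so this position responds to how the ring is attached and not only to its presence. Set against the methyl group, cyclopentyl on the saturated chain carbon gave a 10-fold lower number from compound 1 to compound 4 (1.01 log units; beyond the scatter), a large step from a single change at this nitrogen. Nothing shown here gives a reason for either step. Going by these compounds, whether a longer chain such as cyclopentylethyl, a larger ring as in cyclohexylmethyl, or an amine on the chain would lower the number further remains open.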